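The compounds below may be only part of what the source reports. "The series", "measured", "known", "first", "only" and "open" are said of these compounds alone.

Working notes on the series.

Compound 1, `CNC(=O)c1ccc(-c2cnc(NCc3c(F)ccc4c3CCO4)c3cn[nH]c(=O)c23)c(C)n1`, is the reference point here. Among the measured compounds shown here, in a physicochemical assay for lipophilicity, using the shake flask method, in phosphate buffer, measured as octanol-water partition, with a stated time of 30 min, at pH 7.4 (on this read-out lower numbers stand for lower lipophilicity and higher numbers for higher lipophilicity), compound 1 gives 2.9, the highest of the three numbers so far. Compound 2, `CC1(C)CC(=O)N(c2cnc(NCc3c(F)ccc4c3CCO4)n3cnnc23)C1`, a different core carrying the same fluorinated dihydrobenzofuran-methylamine side chain, gives 2 in this assay, and compound 3, `CN(c1ccn(C)n1)c1cnc(NCc2c(F)ccc3c2CCO3)n2cnnc12`, gives 1.8. For the measured compounds named here, the only one-place step among the measured compounds is a number 0.20 log units lower from compound 2 to compound 3 (within the scatter). Compound 1 sits above compound 2 and above compound 3 by gaps that are both beyond the scatter.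

Compound 4, `Cc1nc(CO)ccc1-c1cnc(NCc2c(F)ccc3c2CCO3)c2cn[nH]c(=O)c12`, differs from compound 1 in one place: hydroxymethyl in place of methylcarbamoyl on an aromatic carbon. Going by the values given here, no measured step touches this position on the shared core of compound 1, and the single measured step, from compound 2 to compound 3, changes a different group on a different core, so it bears on the present change only as a reminder that small swaps of a polar-looking substituent have moved this assay little. With nothing closer to lean on, the expectation is a step of a number 0.20 log units higher from compound 1 to compound 4 (within the scatter), not clearly beyond the scatter. Compound 4 is therefore estimated at 3.1, with a range from 2.6 to 3.6.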

Compound 4, distribution coefficient: 2.4
Estimate against measurement, compound 4: 0.70 log units above; the whole stated range lies above it.
By their numbers in this assay, from the lowest: compounds 3 and 2 (each within the scatter of the next); then compound 4; then compound 1.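

In this assay, among the compounds shown here, this position is not silent: hydroxymethyl in place of methylcarbamoyl, on the aromatic carbon next to the ring nitrogen, gives a number 0.50 log units lower from compound 1 to compound 4 (beyond the scatter), whereas the one earlier step, a number 0.20 log units lower from compound 2 to compound 3 (within the scatter), is a change on a different core. The substituent goes from 4 heavy atoms to 2 while the counts of hydrogen-bond donors and acceptors stay the same, so on this pair the read-out moves beyond the scatter with those counts unchanged. Nothing measured here accounts for the direction or the size of this step.

The compounds shown leave open whether the step follows the size of the group or its kind, and a carboxylic acid, an aminomethyl group or a longer chain such as hydroxyethyl on the same carbon would help to separate the two. Also open, on these data alone, is whether the same swap moves this read-out by a similar amount on a different core, such as that of compound 2.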